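The compounds below may be only part of what the source reports. "The series", "measured", "known", "first", "only" and "open" are said of these compounds alone.

Measured in an ADME assay on Raji cells (Homo sapiens) for cytotoxicity, read by CellTiter-Glo and resazurin assay, with a stated time of 72 h; on this read-out higher numbers stand for an effect only at larger amounts of compound and lower numbers for an effect already at smaller amounts:
compound 1, `CCOC(=O)CCCCCOc1cccc(CN(C(=O)c2ccc(-c3cccnc3)cc2)C(C)C)c1` — > 26000 nM, a limit.
compound 2, `CCOC(=O)CCCCCOc1cccc(CN(C(=O)c2ccc(-c3cccc(-c4nnc(C)o4)c3)cc2)C(C)C)c1` — > 26000 nM, a limit.
compound 3, `CCOC(=O)CCCCCOc1cccc(CN(C(=O)c2ccc(-c3cccc(OC(F)(F)F)c3)cc2)C(C)C)c1` — > 26000 nM, a limit.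

Compound 3 thus stands at the limit, and so do the other two values, as the limit of > 26000 nM in this assay, at which 3 of the 3 values shown sit, records. The step from compound 3 to compound 4 is 2-fluoro-5-methoxyphenyl in place of 3-(trifluoromethoxy)phenyl on an aromatic carbon, giving `CCOC(=O)CCCCCOc1cccc(CN(C(=O)c2ccc(-c3cc(OC)ccc3F)cc2)C(C)C)c1`. The measured steps a step that the two limits leave unreadable from compound 1 to compound 3 and a step that the two limits leave unreadable from compound 2 to compound 3, like a step that the two limits leave unreadable from compound 1 to compound 2, exchange the group at the same place and remain unreadable, since every value sits at the limit. No readable step bears on the change, so in this assay no step beyond the scatter is expected, most likely a further limit. Compound 4 is estimated at 30000 nM, range 14000 nM to 80000 nM, an expected step that the limit leaves unreadable from compound 3 to compound 4.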

Compound 4, half-maximal effective concentration: > 26000 nM
Compound 4 was reported as a limit; the forecaster's own chance of this, stated with the estimate: 85%; the middle value is on the limit's open side.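

The steps from compound 1, compound 2 and compound 3 to compound 4 cannot be read, since all four values are limits: the limit of > 26000 nM in this assay, at which 4 of the 4 values shown sit.

Left open is how far these compounds actually lie apart in this assay and whether any group at this place gives a measurable value.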